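Chloro to fluoro swap across two related cores

The compounds below may be only part of what the source reports. "The series", "measured", "known", "first", "only" and "open" are said of these compounds alone.

Compound 1 `Clc1ccc(-c2n[nH]cc2N2CCCNCC2)cc1` in an assay on isolated protein for binding affinity to 5-hydroxytryptamine receptor 1E (Homo sapiens) (on this read-out lower numbers stand for stronger inhibition and higher numbers for weaker inhibition), gives > 10000 nM, which is a limit of the assay and not a number.
Compound 2 `Fc1ccc(-c2n[nH]cc2N2CCCNCC2)cc1` in this assay gives > 10000 nM, again a limit.
Compound 3 `Clc1ccccc1-c1n[nH]cc1N1CCNCC1` in this assay gives > 10000 nM, also a limit.

The difference between the core of compound 1 and the core of compound 3 is not broken down here. Within the first core, the change fluoro in place of chloro on an aromatic carbon gives the step that the two limits leave unreadable from compound 1 to compound 2, so no size can be read for it. Among the compounds with values here, the only evidence on the measured values is the limit of > 10000 nM in this assay, at which 3 of the 3 values shown sit.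

Compound 4 `Fc1ccccc1-c1n[nH]cc1N1CCNCC1` is the not yet measured partner of compound 3, differing by fluoro in place of chloro on an aromatic carbon. This is the same kind of change as that from compound 1 to compound 2, but the place differs: para to a large group in the first pair, ortho to a large group in the second.

The step from compound 3 to compound 4 is expected to be a step that the limit leaves unreadable from compound 3 to compound 4, which rests on the observation that every measured value sits at the limit, as the limit of > 10000 nM in this assay, at which 3 of the 3 values shown sit, records. Compound 4 is therefore estimated to give 20000 nM, with a range from 8000 nM to 60000 nM, most likely reported again only as a limit.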

Compound 4, inhibition constant: > 10000 nM
Compound 4 ended at the assay's limit (the forecaster's own chance of this, stated with the estimate: 85%); the middle value is on the limit's open side.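

In this assay compound 4 gives > 10000 nM, a limit and not a number. Compound 3 also sits at a limit, so no step can be read between compound 3 and compound 4: the limit of > 10000 nM in this assay, at which 4 of the 4 values shown sit.

The compounds shown leave open how large the change from chloro to fluoro is in either core, and whether any compound of this series gives a measurable value in this assay.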